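The compounds below may be only part of what the source reports. "The series", "measured", "known", "first", "only" and "open" are said of these compounds alone.

In a functional assay on MKN-28 cells (Homo sapiens) for cytotoxicity, read by MTT assay (on this read-out higher numbers stand for weaker inhibition and lower numbers for stronger inhibition), compound 1 `C=C1C(=O)[C@]23C[C@@]1(F)CC[C@H]2[C@@]12C=CC(=O)[C@](C)(C(=O)O1)[C@H]2[C@@H]3C(=O)OC` carries fluoro on a saturated ring carbon and gives 4100 nM on this measure. Compound 2 `C=C1C(=O)[C@]23C[C@@]1(I)CC[C@H]2[C@@]12C=CC(=O)[C@](C)(C(=O)O1)[C@H]2[C@@H]3C(=O)OC` has iodo on that carbon and gives 6700 nM on the same measure. Among the measured compounds shown here, these are the only two numbers so far, and compound 2 stands within the scatter of compound 1, so neither can be ranked over the other. Compound 3 `C=C1C(=O)[C@]23C[C@@]1(OC)CC[C@H]2[C@@]12C=CC(=O)[C@](C)(C(=O)O1)[C@H]2[C@@H]3C(=O)OC` differs from compound 2 by a single change, methoxy in place of iodo on a saturated ring carbon in all: methoxy in place of iodo on a saturated ring carbon. For the measured compounds named here, the only measured step that bears on this is a 1.6-fold higher number from compound 1 to compound 2 (0.21 log units; within the scatter) with iodo in place of fluoro on that carbon. Going by the values given here, no methoxy compound has a number yet, so this step guides only loosely, and no step beyond the scatter is expected in this assay in either direction. The estimate amounts to an expected 1.2-fold lower number from compound 2 to compound 3 (0.09 log units; within the scatter) on this measure. For compound 3 the expected value is 5500 nM with an estimated range from 2500 nM to 12000 nM for repeat measurements.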

Compound 3, half-maximal inhibitory concentration: 3400 nM
Beside the measured number, compound 3's estimate is 1.6-fold (0.21 log units) above it; low and high end bracket the measured number.
By their numbers in this assay, from the lowest: compounds 3, 1 and 2 (each within the scatter of the next).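

Until now, only two halogens had been compared at this saturated ring carbon. Methoxy is a different kind of group: it has two heavy atoms, carbon and oxygen, and one hydrogen-bond acceptor, where iodo has a single heavy atom and no acceptor, yet in this assay the replacement gives a 2.0-fold lower number from compound 2 to compound 3 (0.29 log units; within the scatter). Measured against fluoro, the same group gives a 1.2-fold lower number from compound 1 to compound 3 (0.08 log units; within the scatter), so across these three compounds, a swap from a halogen to an oxygen-linked group at this carbon produces no change that can be told apart from the scatter of repeated measurements, and no outside measurement is available to account for how close the numbers lie.

From the compounds shown here alone, what remains open is whether any group at this carbon can move the number beyond the scatter, for example an amine, a carboxylic acid or a longer chain such as butoxy. These three compounds also cannot say whether the same small differences would hold in other cell lines, since all of their numbers come from this single cytotoxicity measure.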